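Butyl in Place of Hydrogen on the Aryl Ketone

The source may report more compounds than this note shows. Statements on the series, on what has been measured and on what is new or still open speak of the compounds shown alone.

Of the compounds shown here, two have so far been measured in a functional assay on LS174T cells (Homo sapiens) for inhibition, read by MTT assay, with a stated time of 72 h; on this read-out lower numbers stand for stronger inhibition and higher numbers for weaker inhibition. Compound 1 `O=C(O)/C=C/C(=O)c1ccccc1` gives 45500 nM, the highest of the two numbers, while compound 2 `CCc1cc(CC)c(C(=O)/C=C/C(=O)O)c(CC)c1` gives 7280 nM, a lower number beyond the scatter. Compound 3 `CCCCc1ccc(C(=O)/C=C/C(=O)O)cc1` differs from compound 1 by butyl in place of hydrogen on an aromatic carbon. Among the measured compounds shown here, no step between measured compounds is known; a moderate step toward a lower number, beyond the scatter, is expected. Compound 3 is expected to give 15000 nM, with a range from 5000 nM to 40000 nM. The expected step of a 3.0-fold lower number from compound 1 to compound 3 (0.48 log units; beyond the scatter) is moderate, toward a lower number.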

Compound 3, half-maximal inhibitory concentration: 6740 nM
Compound 3: middle estimate off by 2.2-fold (0.35 log units), on the high side; the measured number falls inside the stated range.
By their numbers in this assay, from the lowest: compounds 3 and 2 (each within the scatter of the next); then compound 1.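

At the aromatic carbon para to a group of 7 heavy atoms, butyl in place of hydrogen gives a 6.8-fold lower number from compound 1 to compound 3 (0.83 log units; beyond the scatter) in this assay, the first step read at a single position. This position therefore tolerates butyl, and the change moves the number beyond the scatter. Nothing measured here accounts for the size of this step.

As far as these compounds go, whether methyl, a longer chain such as hexyl, or an amine at this carbon would move the number as far remains open. So does whether the step depends on chain length at all.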